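This account rests on a few compounds, and the source may have more. Where it says the series, first, only, none or still open, it means among the compounds named here.

Compound 1 `COc1cc(-c2nnc3n2NC(c2ccco2)C(C(=O)c2ccc(Cl)cc2)S3)cc(OC)c1OC` is examined in a functional assay on PC-3 cells (Homo sapiens) for cytotoxicity, read by MTT assay, with a stated time of 48 h (a lower number here means a stronger inhibitor, a higher number a weaker inhibitor), where compound 1 gives 67800 nM, the lowest of the two plain numbers available. Compound 2 `COc1cc(-c2nnc3n2NC(c2cccs2)C(C(=O)c2ccccc2)S3)cc(OC)c1OC` gives 86300 nM, a gap from compound 1 that lies within the scatter. Compound 3 `COc1cc(C(=O)C2Sc3nnc(-c4cc(OC)c(OC)c(OC)c4)n3NC2c2cccs2)cc(OC)c1OC` reaches only the limit of this assay, > 100000 nM. Going by the values given here, the one measured step, an at least 1.1-fold higher number from compound 2 to compound 3 (0.06 log units; that floor lies within the scatter), exchanges the group on the carbonyl carbon and sits at the limit of > 100000 nM in this assay, at which 1 of the 3 values shown sits. Compound 4 `COc1cc(-c2nnc3n2NC(c2ccco2)C(C(=O)c2ccc(C)cc2)S3)cc(OC)c1OC` differs from compound 1 by methyl in place of chloro on an aromatic carbon. Among the compounds with values here, no measured step concerns this exchange, so no shift beyond the scatter is expected in this assay. Compound 4 is therefore expected to give 70000 nM, between 35000 nM and 140000 nM. That would mean an expected step of a 1.0-fold higher number from compound 1 to compound 4 (0.01 log units; within the scatter).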

Compound 4, half-maximal inhibitory concentration: 7500 nM
For compound 4 the middle estimate is 9.3-fold (0.97 log units) above the measured one, and the stated range ends above it.
By their numbers in this assay, from the lowest: compound 4; then compounds 1 and 2 (each within the scatter of the next). At a limit, above all of these: compound 3.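

In this assay, 4-methylphenyl in place of 4-chlorophenyl on the carbonyl gives a 9.0-fold lower number from compound 1 to compound 4 (0.96 log units; beyond the scatter), the only step shown that lies beyond the scatter. The earlier compounds shown here left this ring substituent untested, and a swap of one heavy atom on that ring now proves enough to move the number clearly. Nothing available here explains the shift.

As far as these compounds go, it remains open how an amine or a carboxylic acid at this place would compare with methyl. From the compounds shown here alone, it is also open whether the same exchange would give a similar step with the other groups on the shared core.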